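Quinic-acid-type amides as P-selectin inhibitors: working notes

This account rests on a few compounds, and the source may have more. Where it says the series, first, only, none or still open, it means among the compounds named here.

Measured so far:
compound 1, `O=C(O)CCCNC(=O)[C@]1(O)C[C@@H](O)[C@@H](O)[C@H](O)C1`: 40000000 nM
compound 2, `CCC(C)[C@H](NC(=O)[C@]1(O)C[C@@H](O)[C@@H](O)[C@H](O)C1)C(=O)O`: 19000000 nM

Both compounds carry the same polyhydroxylated core and differ only in the amino-acid-derived part attached to the amide nitrogen. In an assay on HL-60 cells for inhibition of P-selectin (Homo sapiens) (on this read-out lower numbers stand for stronger inhibition and higher numbers for weaker inhibition), compound 1 gives 40000000 nM, the highest of the two numbers recorded. Compound 2 gives 19000000 nM, a lower number, and the gap between the two lies beyond the usual scatter. Within the data shown here, no step between measured compounds that differ in a single place is available, so nothing can be said about the size of effects for one-point changes.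

Compound 3, `O=C(O)[C@H](CO)NC(=O)[C@]1(O)C[C@@H](O)[C@@H](O)[C@H](O)C1`, has not been measured. It is derived from compound 1 by the change (1-carboxy-2-hydroxyethyl in place of 3-carboxypropyl on an amide-type nitrogen). Given that compound 2 with a branched carboxyl-bearing substituent sits at 19000000 nM, a number in the same general region is expected for compound 3, and the step from compound 1 is estimated as a 1.6-fold lower number from compound 1 to compound 3 (0.20 log units; within the scatter), a modest decrease that may not exceed the scatter. For compound 3 the expected value in this assay is 25000000 nM, with a plausible range from 8000000 nM to 80000000 nM.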

Compound 3, half-maximal inhibitory concentration: 19500000 nM
Compound 3: the middle estimate sits 1.3-fold (0.11 log units) above what was measured; the measured number falls inside the stated range.
By their numbers in this assay, from the lowest: compounds 2 and 3 (each within the scatter of the next); then compound 1.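

In this assay, 1-carboxy-2-hydroxyethyl in place of 3-carboxypropyl on the amide-type nitrogen gives a 2.1-fold lower number from compound 1 to compound 3 (0.31 log units; beyond the scatter), so this substituent has a small but readable effect on the read-out, a single-place comparison that the earlier pair of compounds could not give. On the saturated chain carbon bound to an amide-type nitrogen and a carbonyl carbon, hydroxymethyl in place of sec-butyl gives a 1.0-fold higher number from compound 2 to compound 3 (0.01 log units; within the scatter), so these two groups cannot be told apart here, even though they differ markedly in name and atom make-up. No measurement is at hand that bears on the reason for either step.

The step from compound 1 changes the chain and adds a hydroxymethyl group at once, so the shorter carboxyl-bearing chain and the added hydroxyl cannot be separated on these compounds alone. Also open, going by these compounds, are whether a primary amide or methyl ester can stand in place of the carboxylic acid, and whether a larger group on the same chain carbon, such as benzyl, moves the number beyond the scatter.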